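A few compounds are considered here, and "the series" means these few. Any claim that something is new, unique, unknown or untested is made for them only; others in the source may bear on it.

Compound 1 `CCCCc1c(F)c(N)c2c(=O)cc(-c3ccc(N)c(F)c3)oc2c1F`: in a functional assay on MCF7 cells (Homo sapiens) for cytotoxicity, read by neutral red uptake, with a stated time of 3 days (a lower number here means a stronger inhibitor, a higher number a weaker inhibitor), compound 1 gives 8800 nM.
Compound 2 `Nc1ccc(-c2cc(=O)c3c(N)c(F)c(O)c(F)c3o2)cc1F`: in this assay compound 2 gives > 10000 nM, which is a limit of the assay and not a number.
Compound 3 `Nc1ccc(-c2cc(=O)c3c(N)c(F)c(C(=O)O)c(F)c3o2)cc1F`: in this assay compound 3 gives > 10000 nM, again a limit of the assay.

Compound 3 therefore stands at the edge of what this assay reports, and it does not stand there alone, since (the limit of > 10000 nM in this assay, at which 2 of the 3 values shown sit). Compound 4 `CN(C)CCC(=O)OCc1c(F)c(N)c2c(=O)cc(-c3ccc(N)c(F)c3)oc2c1F` differs from compound 3 by (((2-(dimethylamino)ethyl)carbonyl)oxy)methyl in place of carboxy on an aromatic carbon. Within the data shown here, two measured steps touch this position. The step of an at least 1.1-fold higher number from compound 1 to compound 3 (0.05 log units; that floor lies within the scatter) marks the change from butyl to carboxy, and its floor lies within the scatter. The step that the two limits leave unreadable from compound 2 to compound 3 gives no readable size. Compound 1, carrying butyl in this place, gives a readable number of 8800 nM, so a larger group here is compatible with a measured value. Compound 4 is therefore expected to give about 8000 nM in this assay, with a range from 2000 nM to 30000 nM. This estimate means an expected step of an at least 1.2-fold lower number from compound 3 to compound 4 (0.09 log units; that floor lies within the scatter) in this assay.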

Compound 4, half-maximal inhibitory concentration: 19 nM
Compound 4: the middle estimate sits 420-fold (2.62 log units) above what was measured; measured number outside the range, below it.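

In this assay this position, on an aromatic carbon ortho to two fluoro groups and para to a fused ring, turns out to govern the read-out strongly: with (((2-(dimethylamino)ethyl)carbonyl)oxy)methyl there, the one fully readable comparison is a 460-fold lower number from compound 1 to compound 4 (2.67 log units; beyond the scatter), whereas butyl, hydroxy and carboxy had shown no step beyond the scatter. The same change also gives an at least 520-fold lower number from compound 3 to compound 4 (2.72 log units; beyond the scatter) and an at least 520-fold lower number from compound 2 to compound 4 (2.72 log units; beyond the scatter), so it stands out against all three earlier groups. The last two steps are floors, as each starts from a limit of the assay: the limit of > 10000 nM in this assay, at which 2 of the 4 values shown sit.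

The compounds shown leave open which part of the entering group carries the change, the dimethylamino group or the ester. A hydroxymethyl group, an acetoxymethyl group without the amine, or a longer chain ending in a diethylamino group would separate these parts.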